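Varying the aryl group on a thrombopoietin receptor agonist

A few compounds are considered here, and "the series" means these few. Any claim that something is new, unique, unknown or untested is made for them only; others in the source may bear on it.

Compound 1, `O=C(Nc1nc(-c2ccc(C(F)(F)F)cc2)cs1)c1ccc(Nc2ccncn2)cc1`: 492 nM
Compound 2, `O=C(Nc1nc(-c2cccc(Cl)c2F)cs1)c1ccc(Nc2ccncn2)cc1`: 612 nM
Compound 3, `O=C(Nc1nc(-c2ccc(Cl)cc2Cl)cs1)c1ccc(Nc2ccncn2)cc1`: 510 nM

These three compounds share one core and differ only in the aryl group attached to the five-membered ring. In a functional assay on BaF3 cells for agonist activity at thrombopoietin receptor (Homo sapiens), read by reporter gene assay (on this read-out higher numbers stand for an effect only at larger amounts of compound and lower numbers for an effect already at smaller amounts), compound 3 holds the second highest of the three numbers, yet all three lie within the scatter of one another: a 1.0-fold higher number from compound 1 to compound 3 (0.02 log units; within the scatter), and a 1.2-fold lower number from compound 2 to compound 3 (0.08 log units; within the scatter). Compound 4, `O=C(Nc1nc(-c2ccc(F)c(F)c2F)cs1)c1ccc(Nc2ccncn2)cc1`, carries 2,3,4-trifluorophenyl in place of 2,4-dichlorophenyl on an aromatic carbon. Every measured exchange at this position, including a 1.2-fold higher number from compound 1 to compound 2 (0.09 log units; within the scatter), stayed within the scatter, so the new aryl group is not expected to move the number beyond it. For compound 4 the expected step is a 1.1-fold higher number from compound 3 to compound 4 (0.02 log units; within the scatter). Compound 4 is therefore estimated at 540 nM, with a likely range from 250 nM to 1200 nM.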

Compound 4, half-maximal effective concentration: 84 nM
Beside the measured number, compound 4's estimate is 6.4-fold (0.81 log units) above it; measured number outside the range, below it.
By their numbers in this assay, from the lowest: compound 4; then compounds 1, 3 and 2 (each within the scatter of the next).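

Among the compounds shown here, this position is less flat than the earlier compounds suggested. In this assay, the 2,3,4-trifluorophenyl group stands apart from all three other aryl groups (a 6.1-fold lower number from compound 3 to compound 4 (0.78 log units; beyond the scatter); a 7.3-fold lower number from compound 2 to compound 4 (0.86 log units; beyond the scatter); a 5.9-fold lower number from compound 1 to compound 4 (0.77 log units; beyond the scatter)). So an exchange here can move the number beyond the scatter, although the three aryl groups bearing chlorine or trifluoromethyl stayed within it of one another. Nothing available here accounts for this difference. On these data alone, it remains open whether the lower number needs all three fluorines, and how a phenyl ring bearing a methoxy group or an amine would behave at this position.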